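The compounds below may be only part of what the source reports. "The series", "measured", "known", "first", "only" and "open" are said of these compounds alone.

Compound 1 `CC(C)c1cccc(C(C)C)c1NC(=O)CC(=O)OC(c1ccccn1)c1ccccn1`: in an assay on microsomes from intestine for inhibition of acyl-CoA:cholesterol acyltransferase (Oryctolagus cuniculus) (a lower number here means a stronger inhibitor, a higher number a weaker inhibitor), compound 1 gives > 5000 nM, which is a limit of the assay and not a number.
Compound 2 `CC(C)c1cccc(C(C)C)c1NC(=O)CC(=O)O`: in this assay compound 2 likewise gives only the limit > 5000 nM.
Compound 3 `CCCCCCCCCCCCCCCCCCOC(=O)CC(=O)Nc1c(C(C)C)cccc1C(C)C`: in this assay compound 3 gives 53 nM.

Compound 2, the free acid of the series, thus stands at the limit of this assay with no number of its own; it shares that position with compound 1, the two of them sitting at the limit of > 5000 nM in this assay, at which 2 of the 3 values shown sit. Only compound 3, whose ester carries a long saturated chain, gives a number.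

The unmeasured compound 4 `CC(C)c1cccc(C(C)C)c1NC(=O)CC(=O)OC(C)(C)C` differs from compound 2 in a single place: tert-butyl in place of hydrogen on an oxygen next to a carbonyl group. Among the measured compounds shown here, no step between two measured compounds is available for comparison. The only ester that gives a number, compound 3, is a very different ester from the tert-butyl one, and the other ester, compound 1, remains at the limit.

On that basis compound 4 is expected to stay weak. The step that the limit leaves unreadable from compound 2 to compound 4 is expected to be none beyond the scatter, or at most a small gain. Compound 4 is estimated at 8000 nM, with a range from 1500 nM to 40000 nM.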

Compound 4, half-maximal inhibitory concentration: 130 nM
Estimate against measurement, compound 4: 62-fold (1.79 log units) above, and the stated range ends above it.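

In this assay, tert-butyl in place of hydrogen on an oxygen next to a carbonyl group gives an at least 38-fold lower number from compound 2 to compound 4 (1.58 log units; beyond the scatter), and this step marks only a bound on the true change: the limit of > 5000 nM in this assay, at which 2 of the 4 values shown sit. The result shows that the long saturated chain of compound 3 is not needed for a measurable value at this position, since the much shorter tert-butyl ester of compound 4 also gives one. Not every ester does so, however: compound 1 gives > 5000 nM, which is a limit of the assay and not a number.

The compounds shown do not tell whether a methyl, an ethyl or an isopropyl ester would also give a number, or how a chain of intermediate length, such as octyl, would compare with the tert-butyl and long-chain esters. They also leave open whether the ester oxygen itself matters, as a tert-butyl amide or a tert-butyl ketone in the same place would test.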